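Amide aryl swap: dimethoxyphenyl replaced by pyridinyl

This account rests on a few compounds, and the source may have more. Where it says the series, first, only, none or still open, it means among the compounds named here.

In a functional assay on the whole organism (strain C57BL/6) for inhibition, with Mus musculus as the target, read by paw edema, with stated times of 1 h and 4 h, at a dose of 100 mg/kg by the oral route (on this read-out higher numbers stand for more inhibition at the one dose given (going by the name of the read-out) and lower numbers for less inhibition), compound 2 `COc1ccc(NC(=O)CCc2nc(Cc3ccc(NC(C)=O)cc3)no2)cc1OC` gives 95.9%, the highest of the two numbers measured, while compound 1 `CC(=O)Nc1ccc(Cc2noc(CCC(=O)Nc3ccccc3)n2)cc1` gives 34.2%. Compound 3 `CC(=O)Nc1ccc(Cc2noc(CCC(=O)Nc3cccnc3)n2)cc1` differs from compound 2 in one place: pyridin-3-yl in place of 3,4-dimethoxyphenyl on an amide-type nitrogen. Among the compounds with values here, the one measured step bears on it directly, because a number 61.7 percentage points higher from compound 1 to compound 2 (beyond the scatter) shows what the 3,4-dimethoxyphenyl is worth against plain phenyl; taking it away again, even for a pyridin-3-yl, points to a large fall in this assay. Compound 3 is therefore expected to give 50%, within 25% to 78%, an expected step of a number 45.9 percentage points lower from compound 2 to compound 3 (beyond the scatter).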

Compound 3, a percentage reported as inhibition, in the whole organism at one dose (the size of the read-out at that dose, not a potency): 87.7%
Compound 3: middle estimate off by 37.7 percentage points, on the low side; the whole stated range lies below it.
By their numbers in this assay, from the lowest: compound 1; then compounds 3 and 2 (each within the scatter of the next).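

In this assay, the pyridin-3-yl on the amide-type nitrogen gives a number 8.2 percentage points lower from compound 2 to compound 3 (within the scatter), so a high number at this position does not depend on the 3,4-dimethoxyphenyl, and an aromatic ring with one hetero atom serves as well. Against plain phenyl the same group gives a number 53.5 percentage points higher from compound 1 to compound 3 (beyond the scatter), which leaves phenyl as the only one of the three groups with a low number. Nothing available accounts for this difference between pyridin-3-yl and phenyl. From the compounds shown here alone, whether a cyclohexyl or a benzyl group on the amide-type nitrogen would also reach such a number remains open.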